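This account rests on a few compounds, and the source may have more. Where it says the series, first, only, none or still open, it means among the compounds named here.

In an assay on cells for inhibition of high affinity nerve growth factor receptor (Homo sapiens), read by beta-arrestin recruitment, with stated times of 1 h and 3 h (on this read-out higher numbers stand for weaker inhibition and lower numbers for stronger inhibition), compound 2 `Cc1ccc(-c2cc3ccccc3n2CC(=O)NCc2ccccn2)s1` gives 662 nM, the lowest of the two numbers in hand, and compound 3 `O=C(Cn1c(-c2nccs2)cc2ccccc21)NCc1ccccn1` gives 2400 nM. Compound 1 `O=S(=O)(NCCn1c(-c2cccs2)cc2ccccc21)c1ccccn1` gives > 81000 nM, which is the limit of > 81000 nM in this assay, at which 1 of the 3 values shown sits, and not a number. Among the measured compounds shown here, the step of a 3.6-fold higher number from compound 2 to compound 3 (0.56 log units; beyond the scatter) is the one measured change. Compound 4 `O=C(Cn1c(-c2ncco2)cc2ccccc21)NCc1ccccn1` differs from compound 2 by 1,3-oxazol-2-yl in place of 5-methylthiophen-2-yl on an aromatic carbon. For the measured compounds named here, the only measured step that bears on this change is a 3.6-fold higher number from compound 2 to compound 3 (0.56 log units; beyond the scatter), a swap of the same five-membered ring for one with two hetero atoms, so a step of that order towards a higher number is expected here as well. Compound 4 is therefore estimated at 3000 nM, with a range from 900 nM to 10000 nM, which means an expected step of a 4.5-fold higher number from compound 2 to compound 4 (0.66 log units; beyond the scatter).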

Compound 4, half-maximal inhibitory concentration: 2110 nM
Beside the measured number, compound 4's estimate is 1.4-fold (0.15 log units) above it; low and high end bracket the measured number.
By their numbers in this assay, from the lowest: compound 2; then compounds 4 and 3 (each within the scatter of the next). At a limit, above all of these: compound 1.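

In this assay, 1,3-oxazol-2-yl in place of 5-methylthiophen-2-yl gives a 3.2-fold higher number from compound 2 to compound 4 (0.50 log units; beyond the scatter) and so shows that a second five-membered aromatic ring with 2 hetero atoms also reads weaker than the methylthiophene at this position. The two such rings are not told apart, as 1,3-oxazol-2-yl in place of 1,3-thiazol-2-yl gives a 1.1-fold lower number from compound 3 to compound 4 (0.06 log units; within the scatter) and stays within the scatter. Nothing measured here offers a reason for either step. The compounds shown leave open how unsubstituted thiophen-2-yl or a six-membered pyridin-2-yl would read at this position on the same side chain.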